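Thiosemicarbazide series: morpholine to pyrrolidine on the thiocarbonyl

The compounds below may be only part of what the source reports. "The series", "measured", "known", "first", "only" and "open" are said of these compounds alone.

Measured so far:
compound 1 `N/C(=N\NC(=S)N1CCOCC1)c1ccc(F)cn1`, 44.5% in a functional assay on A-375 cells (Homo sapiens) for cytotoxicity, read by MTT assay, with a stated time of 72 h, tested at 1 uM; a lower number here means less inhibition of growth, a higher number more inhibition of growth at the concentration tested
compound 2 `N/C(=N\NC(=S)N1CCOCC1)c1ccccn1`, 26.8% in this assay

Compound 2 stands lowest of the two numbers in this assay; its nearest neighbour is compound 1, and the step of a number 17.7 percentage points lower from compound 1 to compound 2 (beyond the scatter) is beyond the scatter. Compound 3 `N/C(=N\NC(=S)N1CCCC1)c1ccccn1` differs from compound 2 by pyrrolidin-1-yl in place of morpholin-4-yl on a thiocarbonyl carbon. Going by the values given here, no measured step touches this part of the structure, so nothing among the measured steps bears on it directly. With no guidance, the expectation is no step beyond the scatter: compound 3 is estimated at 28% (range 10% to 50%), a step of a number 1.2 percentage points higher from compound 2 to compound 3 (within the scatter) that is expected to stay within the usual variation.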

Compound 3, percent growth inhibition at one concentration: 65.7%
Estimate against measurement, compound 3: 37.7 percentage points below, and the stated range ends below it.
By their numbers in this assay, from the lowest: compound 2; then compound 1; then compound 3.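

In this assay, the group on the thiocarbonyl carbon matters: pyrrolidin-1-yl in place of morpholin-4-yl gives a number 38.9 percentage points higher from compound 2 to compound 3 (beyond the scatter), so this position, untouched by the earlier pair, is not a silent one. The exchange both removes the ring oxygen and changes the ring size, and this single step cannot separate the two. Nothing available explains the change.

Still open, as far as these compounds go, is whether a fluoro group on the aromatic ring would raise the number with pyrrolidin-1-yl in place, and how piperidin-1-yl or open-chain diethylamino would read on this carbon.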